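A few compounds are considered here, and "the series" means these few. Any claim that something is new, unique, unknown or untested is made for them only; others in the source may bear on it.

Working notes on the series. In a physicochemical assay for lipophilicity (a lower number here means a more polar compound, a higher number a more lipophilic compound), compound 1 (`CCCCCCN(CCCCCSc1nc2cc(C)ccc2[nH]1)C(=O)Nc1ccc(F)cc1F`) gives 7.79 and compound 2 (`CCCCCCCN(CCCCCSc1nc(O)c2ccccc2n1)C(=O)Nc1ccc(F)cc1F`) gives 6.17 as the lower of the two numbers. For the measured compounds named here, that gap lies beyond the scatter, but no measured pair differs in one place only, so the series offers no direct step to draw on.

Compound 3 (`CCCCCCCN(CCCCCSc1[nH]cnc2ncnc1-2)C(=O)Nc1ccc(F)cc1F`) has not yet been measured. Going to it from compound 2, the change is a group of 9 heavy atoms (5 carbon, 4 nitrogen; one five-membered aromatic ring with 2 hetero atoms, one six-membered aromatic ring with 2 hetero atoms) in place of a group of 11 heavy atoms (8 carbon, 2 nitrogen, 1 oxygen; one six-membered aromatic ring of carbon only, one six-membered aromatic ring with 2 hetero atoms), on a sulfur and the rest of the structure stays. The leaving 4-hydroxyquinazolin-2-yl holds one six-membered aromatic ring of carbon only, while the entering group, which has no common name, holds one five-membered aromatic ring with 2 hetero atoms.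

With only the structural change to go on, a downward step beyond the scatter is expected in this assay and the margin has to stay wide. The expected step is a number 0.97 log units lower from compound 2 to compound 3 (beyond the scatter) as a rough estimate. For compound 3 the estimated value is 5.2 (range 4.4 to 6).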

Compound 3, partition coefficient: 5.32
For compound 3 the middle estimate is 0.12 log units below the measured one; the range from low to high includes it.
By their numbers in this assay, from the lowest: compound 3; then compound 2; then compound 1.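

The series now has its first step in a single place: in this assay, exchanging 4-hydroxyquinazolin-2-yl on the sulfur for the group with no common name gives a number 0.85 log units lower from compound 2 to compound 3 (beyond the scatter), so the read-out responds to what sits at this position. Both groups carry 1 hydrogen-bond donor, 3 hydrogen-bond acceptors and no net charge, so the step arises with those counts unchanged, while the entering group has fewer heavy atoms than the leaving one and a six-membered aromatic ring of carbon only gives way to a five-membered aromatic ring with 2 hetero atoms. No supporting information is available to explain the size or direction of this step.

A single exchange of a whole two-ring group cannot show how much of the step belongs to the ring change, the hydroxy group or the altered nitrogen content. It also leaves open how this assay would respond to a much simpler group on the same sulfur, such as a primary amine or a carboxylic acid on a short carbon chain.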